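Adding a 3-methylbut-2-en-1-yl group to compound 3

The source may report more compounds than this note shows. Statements on the series, on what has been measured and on what is new or still open speak of the compounds shown alone.

In a toxicity assay on CHO cells (Cricetulus griseus) for cytotoxicity, read by WST assay, with a stated time of 24 h (a lower number here means a stronger inhibitor, a higher number a weaker inhibitor), compound 3 (`CC(C)=CCCC(C)=CCNCCCNCCCCNCCCN`) gives > 150000 nM as its reading, which is a limit. Compound 1 (`CC(C)=CCCC(C)=CCNCCCN1CCCC1=O`) gives > 150000 nM as its reading, which is also a limit. Compound 2 (`CCN(CC)CCCNCCCNCC=C(C)CCC=C(C)C`) yields an actual number, with 30900 nM as its reading. For compound 3 the position is the limit of > 150000 nM in this assay, at which 2 of the 3 values shown sit, and no exact value is known.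

Compound 4 (`CC(C)=CCC/C(C)=C\CCC(C)=CCNCCCNCCCCNCCCN`) is still unmeasured and differs from compound 3 by 3-methylbut-2-en-1-yl in place of hydrogen on a saturated chain carbon bound to a double-bonded chain carbon in a single change. For the measured compounds named here, the one measured step is an at least 4.8-fold higher number from compound 2 to compound 3 (0.68 log units; beyond the scatter) and it concerns a different change, so no measured step covers the group that enters here. It bears on compound 4 only as a guide to how far values in this assay can move within this small series. With compound 3 at a limit, any step that can be read would run towards a lower number, and a step of roughly that same size is expected, with wide uncertainty. The expected change is an at least 3.7-fold lower number from compound 3 to compound 4 (0.57 log units; beyond the scatter) as estimated here. For compound 4 the estimate is 40000 nM with an expected range from 10000 nM to 150000 nM in this measurement.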

Compound 4, half-maximal inhibitory concentration: 143000 nM
Beside the measured number, compound 4's estimate is 3.6-fold (0.55 log units) below it; low and high end bracket the measured number.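

In this assay, placing a 3-methylbut-2-en-1-yl group on a saturated chain carbon bound to a double-bonded chain carbon gives an at least 1.0-fold lower number from compound 3 to compound 4 (0.02 log units; that floor lies within the scatter), and as that floor lies within the scatter, the data do not establish any change from this extension. Compound 3 gives > 150000 nM, which is a limit, and the step can be read only as a floor because of it: the limit of > 150000 nM in this assay, at which 2 of the 4 values shown sit. From the compounds shown here alone, compound 4 gives 143000 nM, which is an exact number and so gives this longer chain a fixed reading in this assay, although the true size of the step from its shorter parent remains unknown.

The compounds shown leave open whether a further 3-methylbut-2-en-1-yl unit, or a saturated chain of the same length in place of the one in compound 4, would bring the reading to a clearly lower number. They also leave open how this longer chain would read with a diethylamino group or a carboxylic acid in place of the primary amine of compound 4.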